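The source may hold more compounds than are shown below. What is called first, only, known or untested is meant among the compounds shown, and "the series" means these compounds.

Measured compounds:
compound 1 `Cc1ccc(-c2csc(NS(=O)(=O)c3ccc(C)cc3)n2)cc1`, 76 nM
compound 2 `COc1ccc(S(=O)(=O)Nc2nc(-c3cccc([N+](=O)[O-])c3)cs2)cc1`, 51 nM

Of the compounds shown here, two have been measured in an assay on isolated protein for inhibition of kynurenine 3-monooxygenase (Rattus norvegicus); a lower number here means a stronger inhibitor, a higher number a weaker inhibitor. Compound 1 gives 76 nM, and compound 2 gives 51 nM. The gap between these two numbers lies within the usual scatter of this assay, so compound 1 is not set apart from compound 2 on what has been measured; there is no ranking to draw from these two values.

Compound 3 `Cc1ccc(S(=O)(=O)Nc2nc(-c3ccc(Cl)c(Cl)c3)cs2)cc1` has not yet been measured in this assay. It differs from compound 1 in one place: 3,4-dichlorophenyl in place of 4-methylphenyl on an aromatic carbon. For the measured compounds named here, no measured pair shows what such a change does in this assay, and the shared core is the same in both compounds.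

With nothing measured to lean on, the step from compound 1 to compound 3 is expected to be small, a 1.3-fold lower number from compound 1 to compound 3 (0.10 log units; within the scatter), and in either direction no further than the scatter. Compound 3 is therefore estimated at 60 nM, with a range from 20 nM to 200 nM.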

Compound 3, half-maximal inhibitory concentration: 56 nM
Beside the measured number, compound 3's estimate is 1.1-fold (0.03 log units) above it, within the range that was stated.
By their numbers in this assay, from the lowest: compounds 2, 3 and 1 (each within the scatter of the next).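

In this assay, the exchange of 4-methylphenyl for 3,4-dichlorophenyl on the aromatic carbon next to the ring nitrogen gives a 1.4-fold lower number from compound 1 to compound 3 (0.13 log units; within the scatter). For the compounds shown here, this is the first step read at this position, and the two groups are not told apart, so here one larger aryl group with two chlorine atoms serves as well as one with a single methyl. No other measurement bears on this result or offers a reason for it.

What the compounds shown leave open is whether this position stays as undemanding when the phenyl ring carries a carboxylic acid or an amine, or when a saturated ring such as cyclohexyl replaces it. They also leave open whether a group that is not a phenyl ring at all, such as a pyridine, would move the number beyond the scatter.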